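The compounds below may be only part of what the source reports. "The series", "measured", "known", "first", "only" and "open" are said of these compounds alone.

Of the compounds shown here, three have been measured in a functional assay on RS4-11 cells (Homo sapiens) for inhibition, read by CCK-8 assay, with a stated time of 48 h; on this read-out higher numbers stand for weaker inhibition and lower numbers for stronger inhibition. Compound 1 (`COc1ccc(Oc2ccccc2-c2ccsc2S(=O)(=O)NCCNC(=S)Nc2cc(C(F)(F)F)cc(C(F)(F)F)c2)cc1OC`) gives 3300 nM, compound 2 (`CC(C)c1ccc(Oc2ccc(O)c(O)c2)c(-c2ccsc2S(=O)(=O)NCCNC(=O)Nc2cc(Cl)cc(Cl)c2)c1`) gives 6400 nM, and compound 3 (`COc1ccc(Oc2ccc(C(C)C)cc2-c2ccsc2S(=O)(=O)NCCNC(=S)Nc2cc(C(F)(F)F)cc(C(F)(F)F)c2)cc1OC`) gives 5500 nM. All three numbers lie within the scatter of one another, so compound 1 is not set apart from either of the others.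

Compound 4 (`O=S(=O)(NCCNC(=S)Nc1cc(C(F)(F)F)cc(C(F)(F)F)c1)c1sccc1-c1ccccc1Oc1ccc(O)c(O)c1`) has not yet been measured. It departs from compound 1 by one exchange: 3,4-dihydroxyphenyl in place of 3,4-dimethoxyphenyl on an oxygen on an aromatic ring. In words, this is 3,4-dihydroxyphenyl in place of 3,4-dimethoxyphenyl on an oxygen on an aromatic ring.

Among the compounds with values here, no measured step makes this exchange. Within the data shown here, the only step available, a 1.7-fold higher number from compound 1 to compound 3 (0.22 log units; within the scatter), is isopropyl in place of hydrogen on an aromatic carbon, a different change. Compound 2 does carry the 3,4-dihydroxyphenyl group, but it differs from compound 3 in more than that group, so the closeness of their two values isolates nothing. With every measured number inside the scatter, no step beyond the scatter is expected in this assay, and no direction can be argued with confidence. The expected change is a 1.1-fold lower number from compound 1 to compound 4 (0.04 log units; within the scatter), an estimated step within the scatter. For compound 4 the estimated value is 3000 nM, with an expected range from 1100 nM to 8000 nM.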

Compound 4, half-maximal inhibitory concentration: 4800 nM
Compound 4: middle estimate off by 1.6-fold (0.20 log units), on the low side; the measured number falls inside the stated range.
By their numbers in this assay, from the lowest: compounds 1, 4, 3 and 2 (each within the scatter of the next).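

In this assay, setting 3,4-dihydroxyphenyl in place of 3,4-dimethoxyphenyl on an oxygen on an aromatic ring gives a 1.5-fold higher number from compound 1 to compound 4 (0.16 log units; within the scatter). Within the data shown here, this is the first step that isolates this position, since the only earlier step concerned isopropyl on an aromatic carbon, and compound 2 differed from compound 3 in more than this group; it shows that the 3,4-dimethoxyphenyl group can give way to one carrying hydrogen-bond donors with the two values staying within the scatter of each other. No available evidence bears on the reason for this result.

The compounds shown leave open whether the same exchange would also stay within the scatter on the isopropyl-bearing compound 3, the only other compound here that carries the 3,4-dimethoxyphenyl group. They also leave open whether any group at this oxygen can move the number beyond the scatter, for instance a phenyl ring bearing a carboxylic acid or an amine, or a longer chain ending in a hydroxyl, in place of the 3,4-dihydroxyphenyl group.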